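Cinnamamide-linked trimethoxybenzophenones: removing one methoxy

A few compounds are considered here, and "the series" means these few. Any claim that something is new, unique, unknown or untested is made for them only; others in the source may bear on it.

Three compounds of the series have a number in a functional assay on HT-29 cells (Homo sapiens) for cytotoxicity, read by MTT assay, with a stated time of 72 h; on this read-out lower numbers stand for stronger inhibition and higher numbers for weaker inhibition. Compound 1 `COc1ccc(C(=O)c2cc(OC)c(OC)c(OC)c2)cc1NC(=O)/C=C/c1ccc(F)cc1` gives 1800 nM. Compound 2 `COc1cc(/C=C/C(=O)Nc2cc(C(=O)c3cc(OC)c(OC)c(OC)c3)ccc2OC)ccc1F` gives 7700 nM. Compound 3 `COc1cc(C(=O)c2cc(OC)c(OC)c(OC)c2)cc(NC(=O)/C=C/c2cc(OC)c(OC)c(OC)c2)c1OC` gives 3100 nM; the difference between the cores of compound 2 and compound 3 is not broken down here. Within the data shown here, the only single change measured so far, (hydrogen in place of methoxy on an aromatic carbon), made a 4.3-fold lower number from compound 2 to compound 1 (0.63 log units; beyond the scatter).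

Compound 4 `COc1ccc(/C=C/C(=O)Nc2cc(C(=O)c3cc(OC)c(OC)c(OC)c3)cc(OC)c2OC)cc1OC` is not yet measured. From compound 3 it differs by hydrogen in place of methoxy on an aromatic carbon. This is the same kind of change as from compound 2 to compound 1, but not the same: there the leaving methoxy sat ortho to a fluoro group and meta to a large group, here it sits ortho to a methoxy group, meta to a large group and meta to a methoxy group, and the surrounding ring of compound 3 differs from that of compound 2.

With only one prior occurrence, made in different surroundings, a smaller move than a 4.3-fold lower number from compound 2 to compound 1 (0.63 log units; beyond the scatter) is expected, in the same direction: a 1.9-fold lower number from compound 3 to compound 4 (0.29 log units; within the scatter). Compound 4 is therefore estimated at 1600 nM, plausibly between 600 nM and 4500 nM.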

Compound 4, half-maximal inhibitory concentration: 2300 nM
Compound 4: middle estimate off by 1.4-fold (0.16 log units), on the low side; measured number inside the range.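

Taking 3,4,5-trimethoxyphenyl to 3,4-dimethoxyphenyl in this assay gave a 1.3-fold lower number from compound 3 to compound 4 (0.13 log units; within the scatter) and so leaves compound 3 and compound 4 not separated on this read-out. Among these compounds, with only two pairs, the data give no rule for other cores and do not tell whether the surroundings of the leaving methoxy or the remainder of each core set the size of the step. They do show that the size of the step seen on one core cannot simply be carried to the other: the same change on two cores in this assay, a 4.3-fold lower number (0.63 log units; beyond the scatter) from compound 2 to compound 1 and a 1.3-fold lower number (0.13 log units; within the scatter) from compound 3 to compound 4, 3.2-fold (0.50 log units) apart, beyond the scatter of two such steps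

The compounds shown leave open what other groups would do in place of this methoxy, since only methoxy and hydrogen appear there; a hydroxy group, an amine or a longer ethoxy chain would test whether the outcome depends on the group itself. Also open, as far as these compounds go, is whether a third core would follow the larger step, the smaller step or neither.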